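Phenyl in place of methyl on a sulfonyl hydrazide thiazole

The source may report more compounds than this note shows. Statements on the series, on what has been measured and on what is new or still open speak of the compounds shown alone.

The series begins with compound 1 `Cc1ccc(S(=O)(=O)NNC(N)=S)cc1`, a thiosemicarbazide bearing a tolylsulfonyl group, which in a functional assay on DU-145 cells (Homo sapiens) for inhibition, read by XTT assay, with a stated time of 72 h (on this read-out higher numbers stand for weaker inhibition and lower numbers for stronger inhibition), gives 8980 nM. Compound 2 `Cc1ccc(S(=O)(=O)NNc2nc(C)cs2)cc1` carries a methyl-substituted five-membered aromatic ring in place of the thiocarbamoyl group; in this assay compound 2 gives 6960 nM. The step of a 1.3-fold lower number from compound 1 to compound 2 (0.11 log units; within the scatter) shows that this ring exchange left the read-out essentially unchanged. On the two numbers available compound 2 holds the lowest value, yet its distance from compound 1 is within the scatter, so no order between them can be claimed.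

Compound 3 `Cc1ccc(S(=O)(=O)NNc2nc(-c3ccccc3)cs2)cc1` introduces the change (phenyl in place of methyl on an aromatic carbon). Among the measured compounds shown here, none of the measured steps concerns a phenyl in place of a methyl; the single measured step from compound 1 to compound 2 describes a different exchange and was itself within the scatter, so it offers no direct guide to the size or direction of this change. With no bearing data, a modest shift in this assay is expected for compound 3, on the order of a 1.7-fold lower number from compound 2 to compound 3 (0.24 log units; within the scatter). Compound 3 is therefore estimated at 4000 nM, with a range from 1500 nM to 12000 nM.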

Compound 3, half-maximal inhibitory concentration: 9070 nM
Compound 3: the middle estimate sits 2.3-fold (0.36 log units) below what was measured; the range from low to high includes it.
By their numbers in this assay, from the lowest: compounds 2, 1 and 3 (each within the scatter of the next).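

Among the compounds shown here, this is the first measured step at this position, on an aromatic carbon of a five-membered aromatic ring with 1 nitrogen and 1 sulfur, next to the ring nitrogen, and in this assay phenyl in place of methyl reads as a 1.3-fold higher number from compound 2 to compound 3 (0.11 log units; within the scatter) and stays within the scatter. At this position, then, a phenyl with its six-membered aromatic ring of carbon only can stand in place of a methyl, and the read-out does not separate compound 2 from compound 3. No measurement at hand bears on why the two compounds read alike.

The compounds shown leave open whether any group at this position can move the read-out beyond the scatter, since methyl and phenyl are the only two groups compared here. A longer chain such as propyl at this position, or an amine or a carboxylic acid carried on the phenyl, would test whether this position responds at all in this assay.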